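The compounds below may be only part of what the source reports. "The series", "measured", "known", "first", "only" and "open" are said of these compounds alone.

The two measured compounds share one core and the same chain ending in a hydroxy, attached through different atoms at the aromatic carbon. Compound 1 `CSc1cnc2ccccc2c1[Se]CC#CCO` carries it through selenium, and in a functional assay on B16 cells (Mus musculus) for antiproliferative activity, with a stated time of 72 h (a higher number here means a weaker inhibitor, a lower number a stronger inhibitor), compound 1 gives 4.2 ug/mL. Compound 2 `CSc1cnc2ccccc2c1SCC#CCO` carries it through sulfur, and in this assay compound 2 gives 49.8 ug/mL. Going by the values given here, their single step reads a 12-fold higher number from compound 1 to compound 2 (1.07 log units; beyond the scatter). Compound 2 therefore holds the highest of the two numbers and is the weaker of the two measured inhibitors.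

Compound 3 `CSc1cnc2ccccc2c1SCC#CCCl` is derived from compound 2 by chloro in place of hydroxy on a saturated chain carbon bound to a triple-bonded carbon. Among the compounds with values here, no measured step touches this kind of change: the one step available concerns sulfur in place of selenium on the aromatic carbon and says nothing about a chloro in place of a hydroxy. With nothing in the data pointing either way, the expected change in this assay is none beyond the scatter, and the estimate for compound 3 in this assay is 40 ug/mL, with a range from 13 ug/mL to 120 ug/mL. That estimate amounts to an expected step of a 1.2-fold lower number from compound 2 to compound 3 (0.10 log units; within the scatter) and carries wide uncertainty.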

Compound 3, concentration for 50% inhibition: 16.9 ug/mL
Beside the measured number, compound 3's estimate is 2.4-fold (0.37 log units) above it; the measured number falls inside the stated range.
By their numbers in this assay, from the lowest: compound 1; then compound 3; then compound 2.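

In this assay, the saturated chain carbon bound to a triple-bonded carbon proves sensitive to what it carries: with the sulfur link held fixed, chloro in place of hydroxy gives a real shift (a 2.9-fold lower number from compound 2 to compound 3 (0.47 log units; beyond the scatter)), something the earlier step, confined to the atom linking the chain to the core, could not show. Activity therefore depends on the group on this chain as well as on the linking atom, and the exchange leaves compound 3 the stronger inhibitor of the sulfur-linked pair. Even so, compound 3 does not reach compound 1 (a 4.0-fold higher number from compound 1 to compound 3 (0.60 log units; beyond the scatter)), a step that combines the change of linking atom with the change of group, and no measurement at hand accounts for either shift.

On these data alone, whether chloro in place of hydroxy acts in the same way on the selenium-linked chain of compound 1 remains open, so the two changes cannot yet be taken as adding up. Also open, as far as these compounds go, is whether an amine, a methoxy or a bromo on this carbon, a longer chain, or a chain without the triple bond would go beyond chloro.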